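The source may hold more compounds than are shown below. What is called first, only, known or untested is meant among the compounds shown, and "the series" means these compounds.

Measured compounds:
compound 1 `CCCN(CCC)c1nc(C(F)(F)F)ccc1CNC(=O)C(C)c1ccc(NS(C)(=O)=O)c(F)c1` gives 0.2 nM
compound 2 `C[C@H](C(=O)NCc1ccc(C(F)(F)F)nc1N1CC[C@@H](OCc2ccccc2)C1)c1ccc(NS(C)(=O)=O)c(F)c1` gives 1.4 nM
compound 3 `C[C@@H](C(=O)NCc1ccc(C(F)(F)F)nc1N1CCC(c2ccccc2)CC1)c1ccc(NS(C)(=O)=O)c(F)c1` gives 7.5 nM

All three were measured in a functional assay on CHO-K1 cells for antagonist activity at transient receptor potential cation channel subfamily V member 1 (Homo sapiens), read by FLIPR; on this read-out lower numbers stand for stronger inhibition and higher numbers for weaker inhibition. Compound 1 has the lowest number of the three; compound 2 sits nearest to it and compound 3 furthest, both gaps beyond the scatter. Compound 4 `CC(C(=O)NCc1ccc(C(F)(F)F)nc1N1CCC(O)CC1)c1ccc(NS(C)(=O)=O)c(F)c1` is not yet measured. It differs from compound 1 in one place: 4-hydroxypiperidin-1-yl in place of dipropylamino on an aromatic carbon. Among the measured compounds shown here, no step between measured compounds is available for this change. The two other ring amines, compound 2 with 1.4 nM and compound 3 with 7.5 nM, both give higher numbers than compound 1, so for compound 4 a step toward a higher number, moderate and beyond the scatter, is expected: a 15-fold higher number from compound 1 to compound 4 (1.18 log units; beyond the scatter). The estimate for compound 4 is 3 nM, expected between 0.5 nM and 20 nM.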

Compound 4, inhibition constant: "not active" (no number reported)
Nothing numeric was reported for compound 4; the estimate stays without a comparison.
By their numbers in this assay, from the lowest: compound 1; then compound 2; then compound 3.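

Among the compounds shown here, compound 4 is reported as not active, without a number, in this assay so no step from compound 1 to compound 4 can be read. No available evidence bears on this result. The compounds shown leave open whether the ring or the hydroxy group of 4-hydroxypiperidin-1-yl goes with it.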